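Swapping the amide side chain of compound 3 for propargyl

This account rests on a few compounds, and the source may have more. Where it says the series, first, only, none or still open, it means among the compounds named here.

Measured so far in a functional assay on PC-3 cells (Homo sapiens), read by MTT assay, with a stated time of 48 h (on this read-out higher numbers stand for weaker inhibition and lower numbers for stronger inhibition), are:
- compound 1 `CCN(CC)CCNC(=O)c1ccc(C(CC)(CC)c2ccc(OCC(=O)C(C)(C)C)c(C)c2)n1CC` with 30 nM
- compound 2 `CCN(CC)CCCNC(=O)c1ccc(C(CC)(CC)c2ccc(OCC(=O)C(C)(C)C)c(C)c2)n1CC` with 1800 nM
- compound 3 `CCN(CC)CCNC(=O)c1ccc(C(CC)(CC)c2ccc(OCC(O)C(C)(C)C)c(C)c2)n1CC` with 220 nM

Compound 3 holds the middle of the three numbers, higher than compound 1 and lower than compound 2. Compound 4 `C#CCNC(=O)c1ccc(C(CC)(CC)c2ccc(OCC(O)C(C)(C)C)c(C)c2)n1CC` carries ethynyl in place of (diethylamino)methyl on a saturated chain carbon bound to an amide-type nitrogen. The step of a 60-fold higher number from compound 1 to compound 2 (1.78 log units; beyond the scatter) is large and falls on this same chain, while the step of a 7.3-fold higher number from compound 1 to compound 3 (0.87 log units; beyond the scatter) is modest and concerns another group. For the measured compounds named here, neither removes the diethylamino group, so no measured step shows this change directly. A higher number of modest to large size is therefore expected in this assay with wide uncertainty. The estimated step is as follows (a 4.5-fold higher number from compound 3 to compound 4 (0.66 log units; beyond the scatter)). The expected value for compound 4 is 1000 nM (estimated range 200 nM to 6000 nM).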

Compound 4, half-maximal inhibitory concentration: 16200 nM
Beside the measured number, compound 4's estimate is 16-fold (1.21 log units) below it; the measured number lies above the stated range.
By their numbers in this assay, from the lowest: compound 1; then compound 3; then compound 2; then compound 4.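

In this assay, replacing 2-(diethylamino)ethyl with propargyl on the amide-type nitrogen gives a 74-fold higher number from compound 3 to compound 4 (1.87 log units; beyond the scatter). The earlier 60-fold higher number from compound 1 to compound 2 (1.78 log units; beyond the scatter) showed sensitivity to the length of this chain with the diethylamino group retained, whereas this step shows that a change removing the diethylamino group also costs heavily. The data offer no measured explanation for this step.

The compounds shown leave open whether the amine or the alkyne accounts for the shift, which a plain propyl or a 2-(dimethylamino)ethyl chain could help separate. From the compounds shown here alone, it also remains open whether propargyl has the same effect alongside the (tert-butyl)carbonyl group of compound 1.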